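The source may report more compounds than this note shows. Statements on the series, on what has been measured and on what is new or still open speak of the compounds shown alone.

Of the compounds shown here, three sharing one amide core have been measured in an assay on CHO cells for displacement of a labelled ligand from histamine receptor H3 (Macaca mulatta); a lower number here means a stronger inhibitor, a higher number a weaker inhibitor. Compound 1 `Cc1cc(N2CCC(N3CCCC3C)C2)ccc1NC(=O)C1C(C)(C)C1(C)C` gives 37.3 nM. Compound 2 `CC1CCCN1C1CCN(c2ccc(NC(=O)C3CC3)cc2)C1` gives 9.7 nM. Compound 3 `Cc1cc(N2CCC(N3CCCC3C)C2)ccc1NC(=O)C1CCCO1` gives 7.34 nM, the lowest of the three numbers; compound 2 lies nearest to it, within the usual scatter, while compound 1 lies furthest away. Compound 4 `Cc1cc(N2CCC(N3CCCC3C)C2)ccc1NC(=O)C1CC1` has not yet been measured. It differs from compound 3 in one place: cyclopropyl in place of oxolan-2-yl on a carbonyl carbon. For the measured compounds named here, one measured step touches the same place: a 5.1-fold lower number from compound 1 to compound 3 (0.71 log units; beyond the scatter). That step moved from a ring of carbon only to a ring holding one oxygen; the step now in question moves back to a ring of carbon only, though the entering cyclopropyl is not the group that left in compound 1. Compound 2 already carries a cyclopropyl on its carbonyl carbon, on a core without the methyl, and its value and that of compound 3 sit within the scatter of each other. The step of a 1.2-fold higher number from compound 3 to compound 4 (0.09 log units; within the scatter) is therefore expected to stay within the scatter. Compound 4 is estimated at 9 nM, with a range from 4 nM to 20 nM.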

Compound 4, inhibition constant: 9.6 nM
Beside the measured number, compound 4's estimate is 1.1-fold (0.03 log units) below it, within the range that was stated.
By their numbers in this assay, from the lowest: compounds 3, 4 and 2 (each within the scatter of the next); then compound 1.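

In this assay the change from oxolan-2-yl to cyclopropyl on the carbonyl carbon gives a 1.3-fold higher number from compound 3 to compound 4 (0.12 log units; within the scatter) and stays within the scatter, so the ring holding one oxygen and the ring of carbon only cannot be told apart here. Cutting 2,2,3,3-tetramethylcyclopropyl back to plain cyclopropyl gives a 3.9-fold lower number from compound 1 to compound 4 (0.59 log units; beyond the scatter) and lies beyond the scatter, so the higher number of compound 1 goes with that substituted ring and not with a ring of carbon only as such. At a second place, methyl in place of hydrogen on an aromatic carbon gives a 1.0-fold lower number from compound 2 to compound 4 (0.00 log units; within the scatter) with no change beyond the scatter. Nothing available explains these steps.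

Still open, as far as these compounds go, is whether an open chain such as ethyl, or a ring carrying an amine, would keep the number at this level on the carbonyl carbon.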